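Notes on replacing quinolin-3-yl with 1,3-benzothiazol-5-yl

The source may hold more compounds than are shown below. What is called first, only, known or untested is meant among the compounds shown, and "the series" means these compounds.

Measured in a physicochemical assay for solubility, in phosphate buffer, at pH 7.4; on this read-out lower numbers stand for lower solubility and higher numbers for higher solubility:
Compound 1 `CN(C)C1CCN(c2nccnc2OC2CN(c3ccc4ccccc4n3)C2)CC1`: 500000 nM
Compound 2 `c1ccc(-c2nccnc2OC2CN(c3ccc4ccccc4n3)C2)cc1`: < 1000 nM, a limit
Compound 3 `c1ccc2ncc(-c3nccnc3OC3CN(c4ccc5ccccc5n4)C3)cc2c1`: < 1000 nM, a limit

Compound 3 has no number in this assay, and its < 1000 nM is a limit of the assay.

Compound 4 `c1ccc2nc(N3CC(Oc4nccnc4-c4ccc5scnc5c4)C3)ccc2c1` carries 1,3-benzothiazol-5-yl in place of quinolin-3-yl on an aromatic carbon.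

For the measured compounds named here, the nearest precedent is the exchange of one aromatic group for another, a step that the two limits leave unreadable from compound 2 to compound 3, which gives no readable size. Going by the values given here, the only readable steps are an at least 500-fold lower number from compound 1 to compound 2 (2.69 log units; beyond the scatter) and an at least 500-fold lower number from compound 1 to compound 3 (2.69 log units; beyond the scatter). Both are large, and both remove 4-(dimethylamino)piperidin-1-yl, a group absent from compound 3 and compound 4 alike. Neither step therefore points to a large move here. Compound 4 keeps an aromatic group at this place, so its result is expected close to the limit of < 1000 nM in this assay, at which 2 of the 3 values shown sit.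

No step beyond the scatter is expected, and no direction can be assigned. The expected step is a step that the limit leaves unreadable from compound 3 to compound 4, and a report as a limit is the likeliest outcome. For compound 4 the estimated value is 500 nM, with an expected range from 100 nM to 1500 nM.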

Compound 4, solubility: < 1000 nM
Compound 4 ended at the assay's limit; the forecaster's own chance of this, stated with the estimate: 80%; the middle value lies beyond the limit too.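

In this assay compound 4 gives < 1000 nM, which is a limit of the assay and not a number. With 1,3-benzothiazol-5-yl in place of 4-(dimethylamino)piperidin-1-yl, the read-out shows an at least 500-fold lower number from compound 1 to compound 4 (2.69 log units; beyond the scatter), so the large step seen with phenyl and quinolin-3-yl also appears with a group carrying a five-membered aromatic ring with 2 hetero atoms and sulfur. The steps among compound 2, compound 3 and compound 4 cannot be read, and all three aromatic groups at this place, next to the ring nitrogen, now end at the same limit, with compound 1 the only one of the series shown that stands off it: the limit of < 1000 nM in this assay, at which 3 of the 4 values shown sit.

How far the true values of compound 2, compound 3 and compound 4 lie from the limit stays open, and with it any order among these three groups. Also open, on these data alone, is what a non-aromatic group other than 4-(dimethylamino)piperidin-1-yl, such as morpholin-4-yl or a short chain ending in a carboxylic acid, would give at this place on the shared core.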